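This account rests on a few compounds, and the source may have more. Where it says the series, first, only, none or still open, it means among the compounds named here.

Going by the values given here, in an ADME assay on HEK293 cells (Homo sapiens) for cytotoxicity, read by MTT assay, with a stated time of 72 h (a higher number here means a weaker inhibitor, a lower number a stronger inhibitor), two compounds sharing one core have numbers so far. Compound 1 `O=C(CN1CCN(C(=O)c2ccc(Cl)cc2)CC1)N1CCN(CCCc2c[nH]c3ccc(F)cc23)CC1` gives 44500 nM, and compound 2 `COc1ccc(C(=O)N2CCN(CC(=O)N3CCN(CCCc4c[nH]c5ccc(F)cc45)CC3)CC2)cc1` gives 141000 nM, the higher number of the pair. Compound 3 `COc1cccc(C(=O)N2CCN(CC(=O)N3CCN(CCCc4c[nH]c5ccc(F)cc45)CC3)CC2)c1` differs from compound 2 in one place: 3-methoxyphenyl in place of 4-methoxyphenyl on a carbonyl carbon. In words, it carries 3-methoxyphenyl in place of 4-methoxyphenyl on a carbonyl carbon, so the two have the same atoms, joined differently.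

Among the compounds with values here, only one measured step bears on this, and only indirectly. With methoxy in place of chloro on an aromatic carbon, the numbers show a 3.2-fold higher number from compound 1 to compound 2 (0.50 log units; beyond the scatter), a modest step beyond the scatter. Within the data shown here, that step exchanged one group for another, whereas here the methoxy group remains, and no measured pair shows what a change of this kind does in this assay. A step no larger than that modest one is therefore expected, most likely none beyond the scatter, with the direction left open by the data.

For compound 3 the estimated value is 110000 nM, with an expected range from 50000 nM to 240000 nM. This estimate means a 1.3-fold lower number from compound 2 to compound 3 (0.11 log units; within the scatter).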

Compound 3, half-maximal inhibitory concentration: 87100 nM
Compound 3: middle estimate off by 1.3-fold (0.10 log units), on the high side; the measured number falls inside the stated range.
By their numbers in this assay, from the lowest: compounds 1, 3 and 2 (each within the scatter of the next, the first and the last beyond it).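

Going by these compounds alone, with 3-methoxyphenyl in place of 4-methoxyphenyl on a carbonyl carbon, this assay gives a 1.6-fold lower number from compound 2 to compound 3 (0.21 log units; within the scatter), the first reading of a methoxy group moved on this ring, and the move cannot be told apart from the scatter. The comparison with the chloro compound also gains a limit: 3-methoxyphenyl in place of 4-chlorophenyl gives a 2.0-fold higher number from compound 1 to compound 3 (0.29 log units; within the scatter), while 4-methoxyphenyl in place of 4-chlorophenyl gave a 3.2-fold higher number from compound 1 to compound 2 (0.50 log units; beyond the scatter), so among these three compounds only compounds 1 and 2 are separated in this assay. No supporting evidence bears on why these numbers fall as they do.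

As far as these compounds go, with only these three aryl groups on the carbonyl carbon, it remains open whether the place of a substituent on this ring matters for any group other than methoxy, as a 3-chlorophenyl group would test. From the compounds shown here alone, it also remains open whether an amine or a carboxylic acid on this ring, or an unsubstituted phenyl group, would give a step beyond the scatter in this assay.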